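Carbamate series: chloro for fluoro on the aryl ring

The source may hold more compounds than are shown below. What is called first, only, known or untested is meant among the compounds shown, and "the series" means these compounds.

In a functional assay on PANC-1 cells (Homo sapiens) for inhibition, read by MTT assay, with a stated time of 24 h, tested at 10 uM (a lower number here means less inhibition, a higher number more inhibition at the concentration tested (going by the name of the read-out)), the measured compounds read as follows:
compound 1 `CC(C)=CCC/C(C)=C/COc1cc(=O)n(CCCO)c2c1CC(C/C=C(\C)CCC=C(C)C)C(C)(C)C2` gives 15.8%
compound 2 `CC(C)=CCC/C(C)=C/CC1Cc2c(OCCCOc3ccc(Cl)cc3)cc(=O)n(CCCO)c2CC1(C)C` gives 25.2%
compound 3 `CC(C)=CCC/C(C)=C/CC1Cc2c(OC(=O)Nc3ccc(F)c(Cl)c3)cc(=O)n(CCCO)c2CC1(C)C` gives 25%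

Compound 3 stands second highest of these three numbers. Its nearest neighbour is compound 2, with a step of a number 0.2 percentage points lower from compound 2 to compound 3 (within the scatter), and its furthest is compound 1, with a step of a number 9.2 percentage points higher from compound 1 to compound 3 (within the scatter); both steps are within the scatter, so the three measured compounds cannot be ranked against each other.

Compound 4 `CC(C)=CCC/C(C)=C/CC1Cc2c(OC(=O)Nc3ccc(Cl)c(Cl)c3)cc(=O)n(CCCO)c2CC1(C)C` differs from compound 3 by chloro in place of fluoro on an aromatic carbon.

Going by the values given here, none of the measured steps concerns a halogen swap on the aryl ring of the carbamoyl group. The steps that do touch the group on the aromatic oxygen exchange it wholesale, from a 3,7-dimethylocta-2,6-dien-1-yl or a 3-(4-chlorophenoxy)propyl to the (3-chloro-4-fluorophenyl)carbamoyl, and both of these, together with a number 9.4 percentage points higher from compound 1 to compound 2 (within the scatter), stay within the scatter. A one-atom change at the far end of the carbamoyl aryl ring is therefore expected to give no step beyond the scatter in this assay.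

For compound 4 the expected value in this assay is 25%, with a range of 12% to 40%, which is an expected step of no change at the digits printed from compound 3 to compound 4 (within the scatter).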

Compound 4, a percentage reported as inhibition, at one concentration (the size of the read-out at that concentration, not a potency): 20%
Beside the measured number, compound 4's estimate is 5 percentage points above it; the range from low to high includes it.
By their numbers in this assay, from the lowest: compounds 1, 4, 3 and 2 (each within the scatter of the next).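

In this assay, chloro in place of fluoro on the aromatic carbon gives a number 5 percentage points lower from compound 3 to compound 4 (within the scatter) as the first step read at this position of the carbamoyl aryl ring, and it lies within the scatter, so the (3,4-dichlorophenyl)carbamoyl and (3-chloro-4-fluorophenyl)carbamoyl groups cannot be told apart here. The (3,4-dichlorophenyl)carbamoyl group on the aromatic oxygen also stays within the scatter of the other groups held there, with a number 5.2 percentage points lower from compound 2 to compound 4 (within the scatter) against 3-(4-chlorophenoxy)propyl and a number 4.2 percentage points higher from compound 1 to compound 4 (within the scatter) against 3,7-dimethylocta-2,6-dien-1-yl, so no group on this oxygen separates from the others so far. No supporting data are available to interpret these steps.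

The four readings at one concentration leave open whether any change at this oxygen can move the number beyond the scatter. An amine or a carboxylic acid on the carbamoyl aryl ring in place of the chloro, or a longer chain in place of the 3-(4-chlorophenoxy)propyl, would test this directly.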